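Benzylselenyl to methylsulfanyl on the bis-acyl isoselenourea core

A few compounds are considered here, and "the series" means these few. Any claim that something is new, unique, unknown or untested is made for them only; others in the source may bear on it.

Compound 3 `O=C(/N=C(/NC(=O)c1cccs1)[Se]Cc1ccccc1)c1cccs1` gives 87400 nM in a functional assay on K562 cells (Homo sapiens) for cytotoxicity, read by MTT assay, with a stated time of 72 h; a lower number here means that less compound is tolerated, a higher number that more compound is tolerated; of the two numbers shown it is the lower, yet compound 2 `O=C(/N=C(/NC(=O)c1cc(-c2ccccc2)nc2ccccc12)[Se]Cc1ccccc1)c1cc(-c2ccccc2)nc2ccccc12` with 88900 nM lies within the scatter of it, so no order between the two can be read. Compound 1 `C[Se]/C(=N\C(=O)c1cccs1)NC(=O)c1cccs1` returns only a limit, > 100000 nM, in this assay. Going by the values given here, the single measured step on this core, an at least 1.1-fold lower number from compound 1 to compound 3 (0.05 log units; that floor lies within the scatter), is small and rests on a limit because of the limit of > 100000 nM in this assay, at which 1 of the 3 values shown sits. Compound 4 `CS/C(=N\C(=O)c1cccs1)NC(=O)c1cccs1` differs from compound 3 by a group of 2 heavy atoms (1 carbon, 1 sulfur; no ring) in place of a group of 8 heavy atoms (7 carbon, 1 selenium; one six-membered aromatic ring of carbon only), on a carbon with a double bond to nitrogen. Among the compounds with values here, two things change at once: the phenyl on the saturated chain carbon is removed, which runs an at least 1.1-fold lower number from compound 1 to compound 3 (0.05 log units; that floor lies within the scatter) backwards and points toward a higher number, and sulfur stands where selenium stood, for which no measured step exists and no size can be given. Compound 4 is therefore expected to give about 100000 nM in this assay, with a range from 45000 nM to 220000 nM. The expected step is a 1.1-fold higher number from compound 3 to compound 4 (0.06 log units; within the scatter), and the result may well come back only as a limit.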

Compound 4, concentration lethal to 50% of the cells: > 100000 nM
Compound 4: only a limit was reported; the forecaster's own chance of this, stated with the estimate: 55%; the middle value sits exactly at the limit.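

Methylsulfanyl in place of the selenium-bearing group with its six-membered aromatic ring, on the carbon with a double bond to nitrogen, gives an at least 1.1-fold higher number from compound 3 to compound 4 (0.05 log units; that floor lies within the scatter), so removing that ring and exchanging selenium for sulfur together produces no change beyond the scatter in this assay. The value of compound 4 is a limit, > 100000 nM. The comparison of compound 1 with compound 4, the only one here with sulfur in place of selenium and nothing else changed, cannot be read: the limit of > 100000 nM in this assay, at which 2 of the 4 values shown sit.

On these data alone, whether sulfur in place of selenium alters the number at all therefore stays open. A benzylsulfanyl group on this carbon would separate the two changes, and an amine or a longer chain there would test whether this position can move the number clear of the limit.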